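Pyrazole nitrogen substituent in an antiproliferative amide series

A few compounds are considered here, and "the series" means these few. Any claim that something is new, unique, unknown or untested is made for them only; others in the source may bear on it.

Measured compounds:
- compound 1, `CNC(=O)N1CCCc2ccc(NC(=O)c3ccc(-c4cnn(C(C)=O)c4)cc3)cc21`, 83.8% in a functional assay on MV4-11 cells (Homo sapiens) for antiproliferative activity, with a stated time of 6 days, tested at 6.25 uM; on this read-out lower numbers stand for a weaker effect and higher numbers for a stronger effect at the one concentration tested
- compound 2, `CNC(=O)N1CCCc2ccc(NC(=O)c3cccc(-c4ccn(S(C)(=O)=O)n4)c3)cc21`, 37% in this assay

Compound 1 carries the 1-acetyl-1H-pyrazol-4-yl group and gives the higher of the two numbers in this assay; compound 2, which differs from it in more than one place, gives a number that lies well beyond the scatter below it. Going by the values given here, no single-change step between measured compounds is available, so the effect of the pyrazole nitrogen substituent alone has not been isolated.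

Compound 3, `CNC(=O)N1CCCc2ccc(NC(=O)c3ccc(-c4cnn(C)c4)cc3)cc21`, is the not yet measured partner of compound 1: methyl in place of acetyl on an aromatic nitrogen. The acetyl leaves, the methyl enters, on the aromatic nitrogen of the five-membered ring with two nitrogens.

Among the compounds with values here, with no measured step of this kind, the expectation for compound 3 rests on compound 1 alone: a step of a number 8.8 percentage points lower from compound 1 to compound 3 (within the scatter), most likely none beyond the scatter or a modest loss, is expected. For compound 3 a value of 75% is estimated, within 50% to 92%.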

Compound 3, a percentage reported as inhibition, at one concentration (the size of the read-out at that concentration, not a potency): 94.4%
Compound 3: middle estimate off by 19.4 percentage points, on the low side, outside the stated range (above it).
By their numbers in this assay, from the lowest: compound 2; then compound 1; then compound 3.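

Going by these compounds alone, exchanging the 1-acetyl-1H-pyrazol-4-yl group for the 1-methyl-1H-pyrazol-4-yl group gives the only single-change reading at this aromatic nitrogen: in this assay the change reads as a number 10.6 percentage points higher from compound 1 to compound 3 (beyond the scatter) and isolates the substituent on that nitrogen, with the rest of compound 1 held constant. At this one tested concentration, the acetyl group with its carbonyl is therefore not needed to keep the read-out high, since the smaller methyl, with one heavy atom and no hydrogen-bond acceptor, gives a modestly larger effect. No measurement shown here accounts for the direction of this step.

From the compounds shown here alone, with only acetyl and methyl compared directly at this nitrogen, it remains open how a bare nitrogen carrying hydrogen, an ethyl group, a longer chain or a chain ending in an amine would read in this assay. The contribution of the methanesulfonyl group in compound 2 also remains unseparated from its other differences, and a single-concentration read-out leaves the potency order of the compounds open.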